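Replacing the piperazine side group with a silicon group

A few compounds are considered here, and "the series" means these few. Any claim that something is new, unique, unknown or untested is made for them only; others in the source may bear on it.

Compound 1 `CCN(CC)C/C1=C/C[C@](C)(CCC=C(C)C)/C=C/[C@@H](OC(=O)C=C(C)C)[C@](C)(O)/C=C/C1=O`: 130 nM
Compound 2 `CC(C)=CCC[C@]1(C)/C=C/[C@@H](OC(=O)C=C(C)C)[C@](C)(O)/C=C/C(=O)/C(CN2CCN(C)CC2)=C\C1`: 550 nM

In a functional assay on MCF7 cells (Homo sapiens) for antiproliferative activity, read by MTT assay, with a stated time of 48 h (on this read-out lower numbers stand for stronger inhibition and higher numbers for weaker inhibition), compound 2 stands at 550 nM as the higher of the two numbers. Compound 3 `CC(C)=CCC[C@]1(C)/C=C/[C@@H](OC(=O)C=C(C)C)[C@](C)(O)/C=C/C(=O)/C(C[Si](C)(C)C(C)(C)C)=C\C1` differs from it by a single change (a group of 7 heavy atoms (6 carbon, 1 silicon; no ring) in place of a group of 7 heavy atoms (5 carbon, 2 nitrogen; one six-membered non-aromatic ring with 2 hetero atoms), on a saturated chain carbon bound to a double-bonded ring carbon) at the same place. Among the compounds with values here, the only measured step there is modest (a 4.2-fold higher number from compound 1 to compound 2 (0.63 log units; beyond the scatter)) and joins two nitrogen-bearing groups. Within the data shown here, no measured compound carries silicon, so the direction is poorly fixed. A step of similar size is expected, tentatively upward (a 1.6-fold higher number from compound 2 to compound 3 (0.21 log units; within the scatter)) in this assay for this change. For compound 3 the estimate is 900 nM with an expected range from 200 nM to 4000 nM overall.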

Compound 3, half-maximal inhibitory concentration: 6040 nM
For compound 3 the middle estimate is 6.7-fold (0.83 log units) below the measured one; the whole stated range lies below it.
By their numbers in this assay, from the lowest: compound 1; then compound 2; then compound 3.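

In this assay, the silicon group of compound 3 is the only group shown at this saturated chain carbon without nitrogen, and it costs far more than the exchange between the two nitrogen-bearing groups (an 11-fold higher number from compound 2 to compound 3 (1.04 log units; beyond the scatter); a 46-fold higher number from compound 1 to compound 3 (1.67 log units; beyond the scatter)). Among these three compounds, then, both nitrogen-bearing groups give stronger inhibition than the silicon group. Nothing available explains this loss. The compounds shown leave open whether the loss follows from the absence of nitrogen or from the silicon itself. An all-carbon 3,3-dimethylbutyl group or a morpholine at this place would separate these readings.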